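The source may report more compounds than this note shows. Statements on the series, on what has been measured and on what is new or still open speak of the compounds shown alone.

Measured so far:

compound 1 `Clc1ccc(COc2nnc(COc3ccc(-c4ccccc4)cc3)o2)c(Cl)c1` — 29.5%
compound 2 `CC(C)Cc1ccc(C(C)c2nnc(COc3ccc(-c4ccccc4)cc3)o2)cc1` — 77.3%
compound 3 `CCCCn1c(S)nnc1COc1ccc(-c2ccccc2)cc1` — 75%

In a functional assay on the whole organism (strain Wistar) for inhibition, with Rattus norvegicus as the target, read by paw edema, with a stated time of 3 h, at a dose of 10 mg/kg by the oral route (a lower number here means less inhibition, a higher number more inhibition at the dose given (going by the name of the read-out)), compound 3 gives 75%, the second highest of the three numbers. Compound 2, with 77.3%, lies within the scatter of compound 3, so the two cannot be ordered. Compound 1, with 29.5%, sits far lower, beyond the scatter, and is the only one of the three that falls clearly away from the others.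

Compound 4 `Cc1ccc(-n2c(S)nnc2COc2ccc(-c3ccccc3)cc2)c(C)c1` is the next member and has not yet been measured in this assay. It differs from compound 3 in one place: 2,4-dimethylphenyl in place of butyl on an aromatic nitrogen. Going by the values given here, no pair among the measured compounds differs at this aromatic nitrogen, so no measured step tells what the exchange of butyl for 2,4-dimethylphenyl does; the only guide is that compound 3 and compound 2, which carry quite different groups on their shared core, both sit high in this assay.

The expectation is therefore a step of no more than the usual scatter, if anything a small move downward, giving a number 5 percentage points lower from compound 3 to compound 4 (within the scatter) as the estimated change from compound 3 to compound 4. Compound 4 is estimated to give 70%, with a likely range from 50% to 85%.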

Compound 4, a percentage reported as inhibition, in the whole organism at one dose (the size of the read-out at that dose, not a potency): 54.5%
Compound 4: the middle estimate sits 15.5 percentage points above what was measured, and the stated range covers the measured number.
By their numbers in this assay, from the lowest: compound 1; then compound 4; then compounds 3 and 2 (each within the scatter of the next).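

Going by these compounds alone, at the aromatic nitrogen, the change from butyl to 2,4-dimethylphenyl gives the first single-place step that can be read in this assay: a number 20.5 percentage points lower from compound 3 to compound 4 (beyond the scatter) shows that the group at this position matters to the size of the read-out. The step is only modest, and compound 4 still gives 54.5% in this assay, so a six-membered aromatic ring of carbon at this position keeps part of the inhibition seen with butyl at this dose. Nothing at hand accounts for the size or direction of this step.

The compounds shown leave open whether the step belongs to the aromatic ring as such or to its two methyl groups, a question that plain phenyl or benzyl on the same nitrogen would address. Also open, as far as these compounds go, are how a shorter chain such as ethyl or a longer one such as hexyl compares with butyl at this nitrogen, and what a methylsulfanyl group in place of the sulfanyl group would do to the number.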